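Swapping the Sulfonamide Heterocycle Before the Result Is Known

The source may report more compounds than this note shows. Statements on the series, on what has been measured and on what is new or still open speak of the compounds shown alone.

Measured so far:
compound 1, `Cc1cc(S(=O)(=O)Nc2ccncn2)c(F)cc1O[C@H]1CCC[C@@H]1c1ccnn1C`: 87%
compound 2, `Cn1nccc1[C@H]1CCC[C@@H]1Oc1cc(F)c(S(=O)(=O)Nc2nccs2)cc1F`: 54%

Both were run in an ADME assay on microsomes from liver (Mus musculus), with a stated time of 0.5 h; on this read-out lower numbers stand for a less stable compound and higher numbers for a more stable compound. In this assay compound 1 gives 87%, whereas compound 2 gives 54%. Compound 2 therefore stands lowest of the two numbers; compound 1 lies higher by a gap that is beyond the usual scatter. The two compounds differ in more than one place, so their values are compared only as they stand, with no single change to credit.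

The next compound is compound 3, `Cc1nsc(NS(=O)(=O)c2cc(F)c(O[C@H]3CCC[C@@H]3c3ccnn3C)cc2F)n1`. Relative to compound 2 the change is 3-methyl-1,2,4-thiadiazol-5-yl in place of 1,3-thiazol-2-yl on a sulfonamide nitrogen. Within the data shown here, no measured pair shows this exchange, so the size of the step is open; a small one, possibly none beyond the scatter, seems the most likely outcome. Compound 3 is estimated at 60%, within a range of 40% to 80%, which as a step means an expected a number 6 percentage points higher from compound 2 to compound 3 (within the scatter).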

Compound 3, percent of the compound remaining in the Mus musculus assay: 69%
Compound 3: middle estimate off by 9 percentage points, on the low side; low and high end bracket the measured number.
By their numbers in the Mus musculus assay, from the lowest: compound 2; then compound 3; then compound 1.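

Among these compounds, with one exchange on the sulfonamide nitrogen as the only difference, the Mus musculus assay gives a number 15 percentage points higher from compound 2 to compound 3 (beyond the scatter), so this is the first comparison in which a change can be tied to one place, and that place clearly matters. In a physicochemical assay for solubility, read by HPLC, measured as thermodynamic solubility, with a stated time of 4 h, at pH 6.8 (on this read-out higher numbers stand for higher solubility and lower numbers for lower solubility), compound 2 gives 250000 nM and compound 3 gives 1800000 nM. The exchange therefore comes with higher solubility as well, with no loss on the microsomal read-out: the measured solubility of compound 2, 250000 nM, and of compound 3, 1800000 nM, a 7.2-fold higher number (0.86 log units; beyond the scatter)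

The exchange alters the ring and adds a methyl group together, so these compounds cannot show which of the two matters. As far as these compounds go, an unsubstituted 1,2,4-thiadiazol-5-yl would separate them, and it remains open whether the same exchange would give a similar step on the core of compound 1.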